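From 2,4-dimethylphenyl to 3-carboxypyridin-2-yl on a sulfur

The source may hold more compounds than are shown below. What is called first, only, known or untested is meant among the compounds shown, and "the series" means these compounds.

For the measured compounds named here, in a functional assay on U2OS cells (Homo sapiens) for antiproliferative activity, read by MTT assay, with a stated time of 72 h (a higher number here means a weaker inhibitor, a lower number a stronger inhibitor), compound 1 `Cc1ccc(SCC(=O)Nc2ccc3nc(NC(=O)c4ccc(C(F)(F)F)cc4)sc3c2)c(C)c1` gives 1000 nM as the only true number so far. Compound 2 `COc1ccc(C(=O)Nc2nnc(SCC(=O)Nc3ccc(Br)cc3)s2)cc1OC` gives the limit > 100000 nM and no number. Compound 3 `O=C(CSc1ncccc1C(=O)O)Nc1ccc2nc(NC(=O)c3ccc(C(F)(F)F)cc3)sc2c1` keeps the core of compound 1 but carries 3-carboxypyridin-2-yl in place of 2,4-dimethylphenyl on a sulfur. Going by the values given here, no measured step bears on this change, so the expectation is a judgement: a weaker compound, with the estimated 6.0-fold higher number from compound 1 to compound 3 (0.78 log units; beyond the scatter) going beyond the scatter. In this assay compound 3 is expected to read 6000 nM with 1500 nM to 30000 nM as its estimated range.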

Compound 3, half-maximal inhibitory concentration: 13600 nM
The estimate for compound 3 lay 2.3-fold (0.36 log units) below the measured number, within the range that was stated.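

Holding the core of compound 1 fixed, putting 3-carboxypyridin-2-yl in place of 2,4-dimethylphenyl on the sulfur gives a 14-fold higher number from compound 1 to compound 3 (1.13 log units; beyond the scatter) in this assay, the first measured step at this position. The position therefore responds to the group it carries, yet compound 3 still gives a true number, 13600 nM, and not a limit. Nothing shown here accounts for the size of this step.

The compounds shown leave open whether the ring nitrogen or the carboxylic acid carries the step. A methyl ester in place of the carboxylic acid, or an unsubstituted pyridin-2-yl on the same sulfur, would begin to separate the two.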